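The source may report more compounds than this note shows. Statements on the series, on what has been measured and on what is new or still open speak of the compounds shown alone.

Measured compounds in an assay for binding affinity to 17-beta-hydroxysteroid dehydrogenase type 1 (Homo sapiens), with a stated time of 20 min, tested at 1 uM; on this read-out lower numbers stand for less inhibition and higher numbers for more inhibition at the one concentration tested (going by the name of the read-out):
compound 2 `CC(=O)Nc1cccc(-c2ccc(CO)cc2)c1` gives < 10%
compound 3 `O=C(Nc1cccc(-c2ccc(CO)cc2)c1)c1ccccc1` gives < 10%
compound 1 `O=C(O)c1ccc(-c2ccc3c(O)cccc3c2)cc1` gives < 10%

Compound 2 stands at a limit of this assay, not at a number. The same is true of compound 3 and of compound 1, so every value shown rests at the limit (the limit of < 10% in this assay, at which 3 of the 3 values shown sit). Compound 4 `CC(=O)Nc1cccc(-c2ccc(O)cc2)c1` differs from compound 2 by hydroxy in place of hydroxymethyl on an aromatic carbon. Within the data shown here, the only measured step, a step that the two limits leave unreadable from compound 2 to compound 3, changes a different part of the molecule and cannot be read in size because both ends are limits; no measured step bears on the hydroxy for hydroxymethyl exchange. Compound 1, which carries a hydroxy on its core, also sits at the limit. Compound 4 is therefore expected to stay at the limit as well, a step that the limit leaves unreadable from compound 2 to compound 4 that means no change beyond the scatter. The estimate for compound 4 is 5%, between 0% and 15%.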

Compound 4, a percentage reported as inhibition, at one concentration (the size of the read-out at that concentration, not a potency): < 10%
Compound 4: a limit, no number (the forecaster's own chance of this, stated with the estimate: 80%); the middle value does not contradict the limit.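

No step can be read between compound 2 and compound 4, as both rest at a limit: the limit of < 10% in this assay, at which 4 of the 4 values shown sit. Which change to the shared core, if any, would lift a compound off that limit in this assay stays open.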